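Removing the chloro from compound 2

The source may hold more compounds than are shown below. What is called first, only, known or untested is meant among the compounds shown, and "the series" means these compounds.

For the measured compounds named here, compound 2 `CCN(C(=O)CC(CC(=O)NCCN1CCCC1)c1ccc(Cl)cc1)C1Cc2ccccc2C1` is the only compound with a number in a functional assay on MCF7 cells (Homo sapiens) for inhibition (a lower number here means a stronger inhibitor, a higher number a weaker inhibitor), where compound 2 gives 20400 nM. Compound 1 `O=C(CC(CC(=O)NC1Cc2ccccc2C1)c1ccccc1)NCCN1CCCC1` gives a limit, > 100000 nM, in this assay. Compound 3 `CCN(C(=O)CC(CC(=O)NCCN1CCCC1)c1ccccc1)C1Cc2ccccc2C1` differs from compound 2 in one place: hydrogen in place of chloro on an aromatic carbon. Going by the values given here, no measured pair shows this single change, so the direction is open; compound 1, which also lacks the chloro among further differences, sits at the limit of > 100000 nM in this assay, at which 1 of the 2 values shown sits. The step of a 2.0-fold higher number from compound 2 to compound 3 (0.29 log units; within the scatter) is expected to be a modest loss, near the edge of the scatter. Compound 3 is estimated at 40000 nM, with a range from 15000 nM to 100000 nM.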

Compound 3, half-maximal inhibitory concentration: > 100000 nM
Compound 3 was reported as a limit; the forecaster's own chance of this, stated with the estimate: 30%; middle value at least 2.5-fold (0.39 log units) from the limit.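

Within this assay the change from 4-chlorophenyl to phenyl gives an at least 4.9-fold higher number from compound 2 to compound 3 (0.69 log units; beyond the scatter) and is the first single change in the series seen to go beyond the scatter. Compound 3 is reported as a limit, so the step has a floor but no full size, and the series collects there: the limit of > 100000 nM in this assay, at which 2 of the 3 values shown sit. The step between compound 1 and compound 3 cannot be read, as both values are limits.

Open, from the compounds shown here alone, is whether bromo, methoxy or trifluoromethyl at this place would hold or improve on compound 2. Also open, going by these compounds, is how the amide hydrogen compares with ethyl when the chloro is present.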